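Vero Tolerance of a Nitrophenyl Analogue Among Limit-Bound Neighbours

The compounds below may be only part of what the source reports. "The series", "measured", "known", "first", "only" and "open" are said of these compounds alone.

Compound 1 `COC(=O)c1cc(-c2cccc(NC(=O)c3ccc(/C=C/C(=O)c4ccccc4Br)cc3)c2)on1` — > 40 ug/mL
Compound 2 `CCOc1ccc(C(=O)/C=C/c2ccc(C(=O)Nc3cccc(-c4cc(C(=O)OC)no4)c3)cc2)cc1` — > 40 ug/mL
Compound 3 `COC(=O)c1cc(-c2cccc(NC(=O)c3ccc(/C=C/C(=O)c4ccccc4O)cc3)c2)on1` — "not determined" (no result reported)

In an ADME assay on Vero cells (Chlorocebus sabaeus) for cytotoxicity, read by MTT assay, with a stated time of 72 h (on this read-out higher numbers stand for lower toxicity in this test and lower numbers for higher toxicity in this test), compound 1 gives > 40 ug/mL, which is a limit of the test and not a number. Compound 2 likewise gives > 40 ug/mL, again a limit. The step that the two limits leave unreadable from compound 1 to compound 2 is therefore unreadable. For compound 3 this assay reports "not determined" (no result reported), so it stands without a number of its own, set between two neighbours that share (the limit of > 40 ug/mL in this assay, at which 2 of the 3 values shown sit). Compound 4 `COC(=O)c1cc(-c2cccc(NC(=O)c3ccc(/C=C/C(=O)c4cccc([N+](=O)[O-])c4)cc3)c2)on1` differs from compound 3 by 3-nitrophenyl in place of 2-hydroxyphenyl on a carbonyl carbon. Among the measured compounds shown here, no measured step bears directly on this change, and both readable values rest at the limit, so no step beyond the scatter is expected in this assay. Compound 4 is therefore estimated at about 45 ug/mL, with a range of 20 ug/mL to 90 ug/mL, most probably reported once more only as a limit.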

Compound 4, half-maximal cytotoxic concentration: > 40 ug/mL
Compound 4: no number, only a limit; the forecaster's own chance of this, stated with the estimate: 70%; the middle value is on the limit's open side.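

In this assay compound 4 gives > 40 ug/mL as a limit and not a number. The steps to it from compound 1 and compound 2 cannot be read. The compounds shown leave open whether changing the group on the carbonyl carbon moves this read-out at all.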